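The compounds below may be only part of what the source reports. "The series", "measured", "known", "first", "only" and "open" are said of these compounds alone.

Measured compounds:
Compound 1, `COc1ncc(-c2ccc3nc(NC4CC4)sc3c2)cc1NS(=O)(=O)c1ccc(F)cc1`, in a functional assay on MCF7 cells (Homo sapiens) for antiproliferative activity, read by MTT assay, with a stated time of 72 h (on this read-out lower numbers stand for stronger inhibition and higher numbers for weaker inhibition), gives 450 nM.
Compound 2, `CCN(CC)CCNC(=O)Nc1nc2ccc(-c3cnc(OC)c(NS(=O)(=O)c4ccc(C)cc4)c3)cc2s1`, in this assay gives 170 nM.

Of these two numbers, compound 1 stands highest; the nearer value, that of compound 2, lies beyond the usual scatter below it, so compound 1 is the weaker inhibitor of the pair. The move from compound 1 to compound 3, `COc1ncc(-c2ccc3nc(NC(=O)NCCN4CCCCC4)sc3c2)cc1NS(=O)(=O)c1ccc(F)cc1`, puts ((2-(piperidin-1-yl)ethyl)carbamoyl in place of cyclopropyl on a nitrogen on an aromatic ring). Compound 2 also carries a carbamoyl-bearing substituent on this nitrogen, but it differs from compound 1 elsewhere as well, so no single comparison isolates this change. Still, a downward step is expected for the change from compound 1 to compound 3 because compound 2 gives 170 nM. Compound 3 is therefore estimated at 200 nM, within a range from 80 nM to 500 nM, the expected step being a 2.3-fold lower number from compound 1 to compound 3 (0.35 log units; beyond the scatter).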

Compound 3, half-maximal inhibitory concentration: 450 nM
Estimate against measurement, compound 3: 2.3-fold (0.35 log units) below; the measured number falls inside the stated range.
By their numbers in this assay, from the lowest: compound 2; then compounds 1 and 3 (each within the scatter of the next).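

In this assay, putting (2-(piperidin-1-yl)ethyl)carbamoyl in place of cyclopropyl on a nitrogen on an aromatic ring brings no change at the digits printed from compound 1 to compound 3 (within the scatter). At this position, then, the small carbon-only ring and the larger group, with its six-membered non-aromatic ring and its hydrogen-bond donor, cannot be told apart in this read-out, on the core of compound 1. No measurement is available that would account for this result.

From the compounds shown here alone, it remains open whether a morpholine ring in place of the piperidin-1-yl, a longer chain, or a carboxylic acid in the same substituent would keep this number or move it. Compound 2 differs from compound 1 and from compound 3 in more than one place, so what sets its number apart cannot be assigned to any single group.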